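The compounds below may be only part of what the source reports. "The series", "measured", "known", "first", "only" and "open" are said of these compounds alone.

Compound 1, `C[C@H](c1ccc(-c2cc(Cl)ccc2-c2nc(=O)o[nH]2)cc1)N(CC1CC1)c1nc2c(C(=O)O)cccc2o1`, gives 1300 ng.h/mL in an ADME assay on the whole organism (Macaca fascicularis) for pharmacokinetics, read by LC-MS, using cassette dosing, at a dose of 1 mg/kg by the oral route; on this read-out higher numbers stand for higher exposure at the dose given and lower numbers for lower exposure.
Compound 2, `CCCCN(c1nc2c(C(=O)NC)cccc2o1)[C@H](C)c1ccc(-c2ccccc2-c2nnn[nH]2)cc1`, gives 25.7 ng.h/mL in this assay.

Of the two measured compounds, compound 2 stands at the lower number, and the distance between compound 2 and compound 1 is well beyond the usual scatter of this assay. The two compounds differ in several places at once, so their gap cannot be tied to any single change.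

Compound 3, `CCCCN(c1nc2c(-c3ccccn3)cccc2o1)[C@H](C)c1ccc(-c2ccccc2-c2nnn[nH]2)cc1`, differs from compound 2 in one place: pyridin-2-yl in place of methylcarbamoyl on an aromatic carbon. Going by the values given here, no measured pair of compounds shows this exact change, so its effect on exposure is not known from the numbers at hand. A step upward from compound 2 to compound 3 of moderate size is expected, as a 2.3-fold higher number from compound 2 to compound 3 (0.37 log units; beyond the scatter), though a change within the scatter would not be surprising. Compound 3 is therefore estimated to give 60 ng.h/mL, with a likely range from 10 ng.h/mL to 400 ng.h/mL.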

Compound 3, area under the concentration-time curve: 248 ng.h/mL
The estimate for compound 3 lay 4.1-fold (0.62 log units) below the measured number, within the range that was stated.
By their numbers in this assay, from the lowest: compound 2; then compound 3; then compound 1.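

In this assay, the group on this aromatic carbon of the shared core can alone move oral exposure by a clear margin: pyridin-2-yl in place of methylcarbamoyl gives a 9.6-fold higher number from compound 2 to compound 3 (0.98 log units; beyond the scatter). The position therefore accepts a six-membered aromatic ring, and exposure does not depend on keeping the methylcarbamoyl, even though the change removes a hydrogen-bond donor and adds a ring. Nothing measured here explains the rise.

This single pair cannot separate the effect of adding a ring from that of losing the donor, nor show whether the ring nitrogen and its location matter. A plain phenyl or a pyridin-3-yl group at this same carbon, with the rest of compound 3 unchanged, would bear directly on those questions.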